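The compounds below may be only part of what the source reports. "The series", "measured", "known", "first", "only" and "open" are said of these compounds alone.

Compound 2 `COc1cc2c(Oc3ccc(NC(=O)c4nn(-c5ccccc5C)c(=O)cc4C)cc3F)ccnc2cc1OCCCN1CCC(C)CC1` stands level with its two neighbours in a functional assay on MKN-45 cells (Homo sapiens) for inhibition, read by MTT assay, with a stated time of 72 h; a higher number here means a weaker inhibitor, a lower number a stronger inhibitor: compound 2 gives 1290 nM, compound 1 `COc1cc2c(Oc3ccc(NC(=O)c4nn(-c5ccccc5C)c(=O)cc4C)cc3F)ccnc2cc1OCCCN1CCCCC1` gives 1310 nM, and compound 3 `COc1cc2c(Oc3ccc(NC(=O)c4nn(-c5ccccc5C)c(=O)cc4C)cc3F)ccnc2cc1OCCCN1CCN(C)CC1` gives 1630 nM. The step of a 1.0-fold lower number from compound 1 to compound 2 (0.01 log units; within the scatter) and the step of a 1.3-fold higher number from compound 2 to compound 3 (0.10 log units; within the scatter) both stay within the scatter, as does the step of a 1.2-fold higher number from compound 1 to compound 3 (0.09 log units; within the scatter). Compound 4 `COc1ccc(-n2nc(C(=O)Nc3ccc(Oc4ccnc5cc(OCCCN6CCC(C)CC6)c(OC)cc45)c(F)c3)c(C)cc2=O)cc1` differs from compound 2 in one place: 4-methoxyphenyl in place of 2-methylphenyl on an aromatic nitrogen. None of the three measured steps bears on this change; each of them alters only the amine at the end of the chain on the shared core, and the group on the aromatic nitrogen is the same in compounds 1, 2 and 3. The measured compounds therefore give no guide to the direction or size of this step, and nothing is known about whether the 4-methoxyphenyl group changes the number beyond the scatter. Going by the values given here, with no comparable step available, the estimate for compound 4 is simply anchored on compound 2, with a wide range: the step of a 1.0-fold higher number from compound 2 to compound 4 (0.00 log units; within the scatter) is expected to be small, and compound 4 is estimated at 1300 nM in this assay, between 450 nM and 3800 nM.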

Compound 4, half-maximal inhibitory concentration: 400 nM
Compound 4: the middle estimate sits 3.3-fold (0.51 log units) above what was measured, and the stated range ends above it.
By their numbers in this assay, from the lowest: compound 4; then compounds 2, 1 and 3 (each within the scatter of the next).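

In this assay, the group on the aromatic nitrogen proves to be a position where the number can move: 4-methoxyphenyl in place of 2-methylphenyl gives a 3.2-fold lower number from compound 2 to compound 4 (0.51 log units; beyond the scatter), whereas the changes of amine among compound 1, compound 2 and compound 3 all stayed within the scatter. This one step removes a methyl group and adds a methoxy group, and the entering 4-methoxyphenyl carries one hydrogen-bond acceptor where the leaving 2-methylphenyl has none. No measurement given here accounts for the lower number.

The compounds shown leave open whether the shift follows the loss of the 2-methyl group or the arrival of the 4-methoxy group, a question that plain phenyl, 4-methylphenyl or 2-methoxyphenyl on this nitrogen would address. They also leave open whether piperidin-1-yl or 4-methylpiperazin-1-yl at the chain end would give a similar number alongside 4-methoxyphenyl.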